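A few compounds are considered here, and "the series" means these few. Any claim that something is new, unique, unknown or untested is made for them only; others in the source may bear on it.

Measured compounds in a functional assay (aorta) with Oryctolagus cuniculus as the target; on this read-out lower numbers stand for stronger inhibition and higher numbers for weaker inhibition:
Compound 1 `CO/C(O)=C1\C(C)=NC(C)=C(C(=O)OCCCN2C(=O)c3ccccc3S2(=O)=O)C1c1ccccc1[N+](=O)[O-]` gives 1.5 nM.
Compound 2 `CCO/C(O)=C1\C(C)=NC(C)=C(C(=O)OCCCN2C(=O)c3ccccc3S2(=O)=O)C1c1ccccc1[N+](=O)[O-]` gives 2.6 nM.
Compound 3 `CC1=NC(C)=C(C(=O)OCCCN2C(=O)c3ccccc3S2(=O)=O)C(c2ccccc2[N+](=O)[O-])/C1=C(\O)OCC1CCCCO1` gives 11.5 nM.

Among these three, compound 2 stands second highest. Its nearest neighbour is compound 1, with a 1.7-fold higher number from compound 1 to compound 2 (0.24 log units; within the scatter), a gap that sits within the scatter, so the two cannot be told apart. Compound 3 lies further away, with a 4.4-fold higher number from compound 2 to compound 3 (0.65 log units; beyond the scatter), a modest weakening beyond the scatter.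

Compound 4 `CCO/C(O)=C1\C(C)=NC(C)=C(C(=O)OCCCN2C(=O)c3ccccc3S2(=O)=O)C1c1cccc(Cl)c1Cl` differs from compound 2 in one place: 2,3-dichlorophenyl in place of 2-nitrophenyl on a saturated ring carbon. Going by the values given here, none of the measured steps touches this part of the molecule; all three change the group on the saturated chain carbon bound to the oxygen on the unsaturated carbon, as in a 7.7-fold higher number from compound 1 to compound 3 (0.88 log units; beyond the scatter). The steps seen so far therefore say nothing direct about exchanging the aromatic ring, and the expectation rests only on the observation that every measured compound of this series is potent in this assay. Compound 4 is estimated to give 3 nM, within a range from 0.5 nM to 20 nM. This corresponds to an expected step of a 1.2-fold higher number from compound 2 to compound 4 (0.06 log units; within the scatter), which is not expected to go beyond the scatter.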

Compound 4, half-maximal inhibitory concentration: 1.8 nM
Compound 4: middle estimate off by 1.7-fold (0.22 log units), on the high side; the measured number falls inside the stated range.
By their numbers in this assay, from the lowest: compounds 1, 4 and 2 (each within the scatter of the next); then compound 3.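

Compound 4 is the first shown in which the aromatic ring on the saturated ring carbon changes, as all earlier steps altered only the group on the saturated chain carbon. In this assay, putting 2,3-dichlorophenyl in place of 2-nitrophenyl gives a 1.4-fold lower number from compound 2 to compound 4 (0.16 log units; within the scatter), so at this position a group counted with 2 hydrogen-bond acceptors and one counted with none cannot be told apart on this read-out. Nothing available explains why these two groups read alike.

Going by these compounds, it remains open whether this ring needs any substituent at all, as an unsubstituted phenyl would show, and how an amine or a carboxylic acid on it would read. On these data alone, it is also open whether 2,3-dichlorophenyl would read the same alongside the other chains, those of compound 1 and compound 3.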